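The source may hold more compounds than are shown below. What is called first, only, known or untested is meant among the compounds shown, and "the series" means these compounds.

Three compounds share the core and differ in one substituent on an aromatic carbon. In a functional assay on MCF7 cells (Homo sapiens) for antiproliferative activity, read by MTT assay, with a stated time of 24 h (a lower number here means a stronger inhibitor, a higher number a weaker inhibitor), compound 1 `Cc1ccc(-c2nn(-c3ccccc3)cc2-c2nc3ccccc3n2S(=O)(=O)c2ccccc2)cc1` gives 830 nM and compound 2 `O=S(=O)(c1ccccc1)n1c(-c2cn(-c3ccccc3)nc2-c2ccc(F)cc2)nc2ccccc21` gives 690 nM while compound 3 `O=S(=O)(c1ccccc1)n1c(-c2cn(-c3ccccc3)nc2-c2ccc(C(F)(F)F)cc2)nc2ccccc21` gives 630 nM and so stands level with both within the scatter. Fluoro in place of methyl is a 1.2-fold lower number from compound 1 to compound 2 (0.08 log units; within the scatter) and trifluoromethyl in place of methyl is a 1.3-fold lower number from compound 1 to compound 3 (0.12 log units; within the scatter) while trifluoromethyl in place of fluoro is a 1.1-fold lower number from compound 2 to compound 3 (0.04 log units; within the scatter) and none of the three separates the compounds.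

Compound 4 `O=S(=O)(c1ccc(F)cc1)n1c(-c2cn(-c3ccccc3)nc2-c2ccc(C(F)(F)F)cc2)nc2ccccc21` carries a single change from compound 3, with phenylsulfonyl becoming (4-fluorophenyl)sulfonyl: fluoro in place of hydrogen on an aromatic carbon (fluoro in place of hydrogen on an aromatic carbon, para to a large group). Going by the values given here, no measured step covers this ring, so the three steps above bear on it only indirectly. They show that substituent swaps elsewhere on compound 3 and its neighbours, such as a 1.3-fold lower number from compound 1 to compound 3 (0.12 log units; within the scatter) for the two end members, leave the numbers flat. An estimated 1.1-fold lower number from compound 3 to compound 4 (0.02 log units; within the scatter) is expected in this assay and no direction beyond the scatter is claimed. For compound 4 the estimated value is 600 nM with an expected range from 300 nM to 1200 nM.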

Compound 4, half-maximal inhibitory concentration: 3120 nM
Estimate against measurement, compound 4: 5.2-fold (0.72 log units) below; measured number outside the range, above it.
By their numbers in this assay, from the lowest: compounds 3, 2 and 1 (each within the scatter of the next); then compound 4.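

Phenylsulfonyl becoming (4-fluorophenyl)sulfonyl moves the number in this assay, with a 5.0-fold higher number from compound 3 to compound 4 (0.69 log units; beyond the scatter), and this is the only step among the compounds shown that lies beyond the scatter, in the direction of a weaker inhibitor. The swaps among methyl, fluoro and trifluoromethyl linking compound 1, compound 2 and compound 3 left the numbers level, whereas this position responds to the entry of one heavy atom in place of hydrogen, so the phenylsulfonyl group cannot be treated as a part of the molecule where changes pass without effect, although that reading rests on this single pair. No measurement at hand accounts for the step, so its origin stays unexplained.

The compounds shown do not tell whether the rise belongs to fluoro itself or would follow any group entering on this aromatic carbon, such as chloro, methoxy or an amine. Nor do they tell whether the same change would give a step of similar size with the methyl of compound 1 or the fluoro of compound 2 in place of the trifluoromethyl of compound 3.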